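Permeability notes: phenoxy in place of trifluoromethylbenzyl

A few compounds are considered here, and "the series" means these few. Any claim that something is new, unique, unknown or untested is made for them only; others in the source may bear on it.

Compound 3 `COc1ccc(F)cc1CNCCCNc1ccnc2cc(Cc3cccc(C(F)(F)F)c3)ccc12` gives 23 10^-6 cm/s in an ADME assay for permeability, using PAMPA, with a stated time of 30 min, at pH 7.4; a higher number here means that the compound crosses the layer faster, a lower number that the compound crosses the layer more slowly. Compound 3 stands level with compound 2 `COc1ccc(F)cc1CNCCCNc1ccnc2cc(CCC(C)C)ccc12`, which gives 23 10^-6 cm/s, and the two together are the lowest of the three numbers, while compound 1 `COc1ccc(Oc2ccc3c(NCCCNCc4cc(F)ccc4OC)ccnc3c2)cc1` gives 317 10^-6 cm/s. Compound 4 `COc1ccc(F)cc1CNCCCNc1ccnc2cc(Oc3ccccc3)ccc12` differs from compound 3 in one place: phenoxy in place of 3-(trifluoromethyl)benzyl on an aromatic carbon. The measured step that bears most on this change is a 14-fold lower number from compound 1 to compound 3 (1.14 log units; beyond the scatter), where 3-(trifluoromethyl)benzyl replaced 4-methoxyphenoxy; a 14-fold lower number from compound 1 to compound 2 (1.14 log units; beyond the scatter) was of the same size, and no change at the digits printed from compound 2 to compound 3 (within the scatter). Compound 4 returns to a phenoxy group, lacking only the methoxy of compound 1, so a rise back toward compound 1 is expected, a 6.5-fold higher number from compound 3 to compound 4 (0.81 log units; beyond the scatter). Compound 4 is therefore estimated at 150 10^-6 cm/s, with a range from 50 10^-6 cm/s to 350 10^-6 cm/s.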

Compound 4, apparent permeability: 317 10^-6 cm/s
Compound 4: the middle estimate sits 2.1-fold (0.32 log units) below what was measured; the range from low to high includes it.
By their numbers in this assay, from the lowest: compounds 2 and 3 (each within the scatter of the next); then compounds 1 and 4 (each within the scatter of the next).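

In this assay the methoxy of compound 1 can go without consequence at this aromatic carbon, with no change at the digits printed from compound 1 to compound 4 (within the scatter) as the step. Phenoxy in place of 3-(trifluoromethyl)benzyl gives a 14-fold higher number from compound 3 to compound 4 (1.14 log units; beyond the scatter) and phenoxy in place of isopentyl gives a 14-fold higher number from compound 2 to compound 4 (1.14 log units; beyond the scatter) as the matching steps. Across these four compounds the phenoxy and 4-methoxyphenoxy groups both stand above the two groups joined through carbon, and no compound goes against this. From the compounds shown here alone, whether a short alkoxy chain or an amine at this carbon would stay at the phenoxy level remains open, as does the effect of a carboxylic acid on the phenoxy ring. No measured evidence on the cause of this gap is at hand.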